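Ortho versus meta trifluoromethyl on the diarylurea

A few compounds are considered here, and "the series" means these few. Any claim that something is new, unique, unknown or untested is made for them only; others in the source may bear on it.

Compound 1 `CN(C)CCn1cnnc1-c1cc(Oc2ccc(NC(=O)Nc3ccccc3C(F)(F)F)cc2F)ccn1`: > 50000 nM. Compound 2 `CCN(CC)CCn1cnnc1-c1cc(Oc2ccc(NC(=O)Nc3cccc(C(F)(F)F)c3)cc2F)ccn1`: 9870 nM.

Within the data shown here, in a functional assay on NCI-H460 cells (Homo sapiens) for antiproliferative activity, read by MTT assay, with a stated time of 72 h (a lower number here means a stronger inhibitor, a higher number a weaker inhibitor), compound 2 gives the only numerical value, 9870 nM. Compound 1 reaches only the limit of the assay, > 50000 nM, as noted in the limit of > 50000 nM in this assay, at which 1 of the 2 values shown sits. Compound 3 `CCN(CC)CCn1cnnc1-c1cc(Oc2ccc(NC(=O)Nc3ccccc3C(F)(F)F)cc2F)ccn1` differs from compound 2 by 2-(trifluoromethyl)phenyl in place of 3-(trifluoromethyl)phenyl on an amide-type nitrogen. Among the measured compounds shown here, no measured step exists for this change; compound 1 carries the same 2-(trifluoromethyl)phenyl. A sizeable loss in this assay is expected, as a 4.1-fold higher number from compound 2 to compound 3 (0.61 log units; beyond the scatter). Compound 3 is estimated at 40000 nM, between 12000 nM and 150000 nM.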

Compound 3, half-maximal inhibitory concentration: > 50000 nM
Compound 3 gave a limit, no number (the forecaster's own chance of this, stated with the estimate: 45%); at least 1.2-fold (0.09 log units) between middle value and limit.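

With the diethylamino chain held constant, 2-(trifluoromethyl)phenyl in place of 3-(trifluoromethyl)phenyl on an amide-type nitrogen gives, in this assay, an at least 5.0-fold higher number from compound 2 to compound 3 (0.70 log units; beyond the scatter). Among these compounds, this is the first measured step at this position, and it sets only a lower bound on the loss, as compound 3 gives a limit and not a number. The step from compound 1 to compound 3, diethylamino in place of dimethylamino, cannot be read, as both compounds sit at the same limit: the limit of > 50000 nM in this assay, at which 2 of the 3 values shown sit.

The compounds shown leave open how a phenyl carrying chlorine or a methoxy group in place of trifluoromethyl would fare on that nitrogen. They also leave open whether a morpholine in place of diethylamino would shift the number in this assay.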